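Series notes: hydrogen in place of methoxy, compound 3

The compounds below may be only part of what the source reports. "The series", "measured", "known", "first", "only" and "open" are said of these compounds alone.

Measured so far:
compound 1 `COc1ccccc1/C=C/C(=O)/C=C/c1ccc(OCc2cn(CCOc3cc(=O)oc4ccccc34)nn2)c(OC)c1`: 7330 nM
compound 2 `COc1cc(/C=C/C(=O)/C=C/c2cc(OC)c(OC)c(OC)c2)ccc1OCc1cn(CCCOc2cc(=O)oc3ccccc23)nn1`: 5430 nM

In a functional assay on THP-1 cells (Homo sapiens) for cytotoxicity, read by sulforhodamine B assay, with a stated time of 48 h (on this read-out lower numbers stand for stronger inhibition and higher numbers for weaker inhibition), compound 1 gives 7330 nM, and compound 2 gives 5430 nM. Compound 2 has the lowest of the two numbers, but the gap to compound 1 lies within the scatter, so no order is claimed. Compound 3 `COc1ccc(/C=C/C(=O)/C=C/c2ccc(OCc3cn(CCCOc4cc(=O)oc5ccccc45)nn3)c(OC)c2)cc1OC` differs from compound 2 by hydrogen in place of methoxy on an aromatic carbon. Among the measured compounds shown here, no step between measured compounds is known for this change, so in this assay a step of a 1.0-fold higher number from compound 2 to compound 3 (0.01 log units; within the scatter) is expected, not beyond the scatter in either direction. Compound 3 is therefore estimated at 5500 nM, with a range from 2500 nM to 12000 nM.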

Compound 3, half-maximal inhibitory concentration: 8510 nM
Compound 3: the middle estimate sits 1.5-fold (0.19 log units) below what was measured; the range from low to high includes it.
By their numbers in this assay, from the lowest: compounds 2, 1 and 3 (each within the scatter of the next).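

In this assay, among the compounds shown here, replacing 3,4,5-trimethoxyphenyl with 3,4-dimethoxyphenyl gives a 1.6-fold higher number from compound 2 to compound 3 (0.20 log units; within the scatter), the only step here between compounds that differ in one place. The methoxy on this aromatic carbon, ortho to a methoxy group, can therefore be exchanged for hydrogen without a shift beyond the scatter. No other data on hand bear on this result.

Still open, as far as these compounds go, is whether an amine or a carboxylic acid on this carbon would move the number beyond the scatter. A single step also leaves open whether this holds on other compounds of the series.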